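The source may hold more compounds than are shown below. What is called first, only, known or untested is meant among the compounds shown, and "the series" means these compounds.

Going by the values given here, in an assay on cell membranes for displacement of a labelled ligand from adenosine receptor A1 (Rattus norvegicus) (a higher number here means a weaker inhibitor, a lower number a stronger inhibitor), compound 2 `OCC1CC=CC1n1cnc2c(NC3CC3)ncnc21` gives 32300 nM, the only single number reported for it; two further determinations of compound 2 returned no number at all. On the same core, compound 1 `CNC(=O)C1CC=CC1n1cnc2c(NCc3ccccc3I)ncnc21` gives 8120 nM; 123000 nM (2 entries) in this assay, and compound 3 `OCC1CC=CC1n1cnc2c(NC3CCCC3)ncnc21` gives 3000 nM; 333000 nM (2 entries); in each case the two entries lie far apart, as the several entries of compound 1 in this assay, 8120 nM; 123000 nM (2 entries) and the several entries of compound 3 in this assay, 3000 nM; 333000 nM (2 entries) show. Compound 4 `OCC1CC=CC1n1cnc2c(NCc3ccccc3I)ncnc21` has not yet been measured. It differs from compound 2 by 2-iodobenzyl in place of cyclopropyl on a nitrogen on an aromatic ring. Compound 1 carries that same 2-iodobenzyl group, and its entries 8120 nM; 123000 nM (2 entries) straddle the value of compound 2. No step beyond the scatter is therefore expected in this assay; the estimated step is a 1.3-fold lower number from compound 2 to compound 4 (0.11 log units; within the scatter). Compound 4 is estimated at 25000 nM, with a range from 4000 nM to 150000 nM.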

Compound 4, inhibition constant: 25500 nM
For compound 4 the middle estimate is 1.0-fold (0.01 log units) below the measured one, and the stated range covers the measured number.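

In this assay, 2-iodobenzyl in place of cyclopropyl on a nitrogen on an aromatic ring gives a 1.3-fold lower number from compound 2 to compound 4 (0.10 log units; within the scatter). Going by these compounds alone, this is the first comparison of compounds that differ in this one place. At this position, a six-membered aromatic ring carrying iodine and a three-membered non-aromatic ring thus give values within the scatter of each other.

As far as these compounds go, whether a carboxylic acid or a longer alkyl chain on this nitrogen would do the same remains open. The entries for compound 3 also lie too far apart to place it against compound 2: the several entries of compound 3 in this assay, 3000 nM; 333000 nM (2 entries)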